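Branched side-chain variants in a lactone series

The compounds below may be only part of what the source reports. "The series", "measured", "known", "first", "only" and "open" are said of these compounds alone.

Measured so far:
compound 1 `CCCCCCCCC/C=C1\CC(CO)(COC(=O)c2cn(C)c3ccccc23)OC1=O` — 59.6 nM
compound 2 `CCCC(/C=C1\CC(CO)(COC(=O)c2cn(C)c3ccccc23)OC1=O)CCC` — 295 nM

In an assay for displacement of a labelled ligand from protein kinase C epsilon type (Homo sapiens), read by scintillation counting, in the presence of a further agent that is not named here (a lower number here means a stronger inhibitor, a higher number a weaker inhibitor), compound 1 gives 59.6 nM, and compound 2 gives 295 nM; compound 2 therefore stands at the higher of the two numbers, the step being a 4.9-fold higher number from compound 1 to compound 2 (0.69 log units; beyond the scatter).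

Compound 3 `CC(C)C(C/C=C1\CC(CO)(COC(=O)c2cn(C)c3ccccc23)OC1=O)C(C)C` differs from compound 2 in one place: 2-isopropyl-3-methylbutyl in place of 1-propylbutyl on a double-bonded chain carbon bound to a double-bonded ring carbon. Going by the values given here, the only measured step that bears on this position is the one from nonyl to 1-propylbutyl, a 4.9-fold higher number from compound 1 to compound 2 (0.69 log units; beyond the scatter), which went upward by a modest amount. No branched-to-branched comparison exists in the series, so the direction of a further change of branching at this carbon cannot be read from the data. The chain of compound 3 is of similar size to that of compound 2, and the expectation in this assay is a step within or near the scatter, a 1.2-fold higher number from compound 2 to compound 3 (0.07 log units; within the scatter), with a wide uncertainty in both directions.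

Compound 3 is therefore estimated at 350 nM in this assay, with a range of 120 nM to 1000 nM.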

Compound 3, inhibition constant: 27.3 nM
The estimate for compound 3 lay 13-fold (1.11 log units) above the measured number, and the stated range ends above it.
By their numbers in this assay, from the lowest: compound 3; then compound 1; then compound 2.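

In this assay, going by these compounds alone, the double-bonded chain carbon bound to a double-bonded ring carbon responds to the shape of a branched chain, and not only to the change from a straight chain to a branched one: 2-isopropyl-3-methylbutyl in place of 1-propylbutyl gives an 11-fold lower number from compound 2 to compound 3 (1.03 log units; beyond the scatter) and is the largest step so far. Branching alone therefore does not raise the number at this position, since the step read against the straight chain is a 2.2-fold lower number from compound 1 to compound 3 (0.34 log units; beyond the scatter) and compound 3 goes against the rise seen with compound 2. No measurement on hand accounts for either step.

On these data alone, whether the gain follows from where the branching begins along the chain or from the isopropyl and methyl end groups remains open, as the two change together in this single step. As far as these compounds go, how a cyclohexyl group, a longer branched chain or a chain ending in a carboxylic acid would read at this position also remains open, as does whether the order of these three compounds would hold with a different ester on the shared core.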